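A Branched Chain Replaces the Ring on Compound 3

The source may report more compounds than this note shows. Statements on the series, on what has been measured and on what is new or still open speak of the compounds shown alone.

Of the compounds shown here, three sharing one core have been tested in a functional assay on the whole organism (blood, strain Wistar-Okamoto) with Rattus norvegicus as the target, with a stated time of 5 days; on this read-out higher numbers stand for an effect only at larger amounts of compound and lower numbers for an effect already at smaller amounts. Compound 1 `CCC/N=C(\NC#N)Nc1cccnc1` gives 20 mg/kg. Compound 2 `CCC(C)/N=C(\NC#N)Nc1cccnc1` gives 20 mg/kg. Compound 3 `N#CN/C(=N\C1CCCCC1)Nc1cccnc1` gives 20 mg/kg. Within the data shown here, compound 3 thus stands level with the other two in this assay, and no step among the three leaves the usual scatter.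

Compound 4 `CCCC(C)(C)/N=C(\NC#N)Nc1cccnc1` differs from compound 3 by 1,1-dimethylbutyl in place of cyclohexyl on a double-bonded nitrogen. Changes at this same double-bonded nitrogen have already been followed: replacing propyl with cyclohexyl gave no change at the digits printed from compound 1 to compound 3 (within the scatter), replacing sec-butyl with cyclohexyl gave no change at the digits printed from compound 2 to compound 3 (within the scatter), and adding a methyl on the chain gave no change at the digits printed from compound 1 to compound 2 (within the scatter). None of these moved the read-out, whether the group was a chain, a branched chain or a ring. For the present exchange of one group of six heavy atoms for another, compound 4 is therefore expected to show no step beyond the scatter, no change at the digits printed from compound 3 to compound 4 (within the scatter). The estimate for compound 4 in this assay is 20 mg/kg, with an expected range from 10 mg/kg to 40 mg/kg.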

Compound 4, minimum effective dose: 1 mg/kg
Estimate against measurement, compound 4: 20-fold (1.30 log units) above; measured number below the stated range.
By their numbers in this assay, from the lowest: compound 4; then compounds 1, 2 and 3 (each within the scatter of the next).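

The position on the double-bonded nitrogen is not indifferent in this assay, although propyl, sec-butyl and cyclohexyl had left the read-out level. Placing 1,1-dimethylbutyl there gives a large step against each earlier group (a 20-fold lower number from compound 3 to compound 4 (1.30 log units; beyond the scatter); a 20-fold lower number from compound 2 to compound 4 (1.30 log units; beyond the scatter); a 20-fold lower number from compound 1 to compound 4 (1.30 log units; beyond the scatter)). Cyclohexyl and 1,1-dimethylbutyl each hold 6 heavy atoms, all carbon, and neither has a hydrogen-bond donor or acceptor, so these counts do not separate the two groups, which differ in the ring and the branching.

As far as these compounds go, whether the shorter tert-butyl or an unbranched hexyl chain would match compound 4 remains open, as does which part of 1,1-dimethylbutyl carries the step. No measurement is available that explains the step.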